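From a sulfamoylphenyl arm to a pyridyl arm

The source may report more compounds than this note shows. Statements on the series, on what has been measured and on what is new or still open speak of the compounds shown alone.

Compound 1 `O=C(O)Cc1sc(C(c2ccc(F)cc2)c2ccc(F)cc2)nc1-c1ccccc1` gives 240 nM in an in vitro functional assay on HEK285-7 cells for antagonist activity at prostaglandin D2 receptor 2 (Homo sapiens), read by BRET and beta-arrestin recruitment; on this read-out lower numbers stand for stronger inhibition and higher numbers for weaker inhibition. Compound 2 `O=C(O)Cc1sc(C(c2ccc(F)cc2)c2ccc(F)cc2)nc1-c1cc(F)cc(F)c1` gives 340 nM in this assay, and the step of a 1.4-fold higher number from compound 1 to compound 2 (0.15 log units; within the scatter). Compound 3 `NS(=O)(=O)c1ccc(-c2nc(C(c3ccc(F)cc3)c3ccc(F)cc3)sc2CC(=O)O)cc1` reaches only a limit, > 100000 nM, in this assay, so no number stands for it. That limit is the limit of > 100000 nM in this assay, at which 1 of the 3 values shown sits. The steps of an at least 410-fold higher number from compound 1 to compound 3 (2.61 log units; beyond the scatter) and an at least 290-fold higher number from compound 2 to compound 3 (2.46 log units; beyond the scatter) show that the sulfamoyl-bearing ring takes away all measurable inhibition. Compound 4 `O=C(O)Cc1sc(C(c2ccc(F)cc2)c2ccc(F)cc2)nc1-c1ccncc1` carries the change (pyridin-4-yl in place of 4-sulfamoylphenyl on an aromatic carbon), which removes that ring again. The expected step of an at least 160-fold lower number from compound 3 to compound 4 (2.22 log units; beyond the scatter) is therefore a large fall in number, since the measured values of compounds 1 and 2 hold small aromatic rings at this place. Compound 4 is expected to give 600 nM, between 150 nM and 3000 nM.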

Compound 4, half-maximal inhibitory concentration: 40 nM
The estimate for compound 4 lay 15-fold (1.18 log units) above the measured number, and the stated range ends above it.
By their numbers in this assay, from the lowest: compound 4; then compounds 1 and 2 (each within the scatter of the next). At a limit, above all of these: compound 3.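

The value of compound 3 is a limit and not a number: the limit of > 100000 nM in this assay, at which 1 of the 4 values shown sits. The step of an at least 2500-fold lower number from compound 3 to compound 4 (3.39 log units; beyond the scatter) therefore gives only a bound, but it shows that this position can carry a ring without a sulfamoyl group and keep measurable inhibition. Compounds 1 and 2 had shown no difference beyond the scatter at this position, whereas pyridin-4-yl gives a real gain over both carbon-only rings, with a 6.0-fold lower number from compound 1 to compound 4 (0.78 log units; beyond the scatter) and an 8.5-fold lower number from compound 2 to compound 4 (0.93 log units; beyond the scatter).

The compounds shown leave open whether pyridin-3-yl or pyridin-2-yl would match pyridin-4-yl. They also leave open whether a pyrimidine ring or an amine on the pyridine ring would hold the lower number.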